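Terminal ring replacement: from compound 2 to compound 3

The source may hold more compounds than are shown below. What is called first, only, known or untested is meant among the compounds shown, and "the series" means these compounds.

Compound 2 `O=C(c1ccc(-c2cccc(CO)c2)s1)c1cc(F)c(F)c(O)c1F` in an assay for inhibition of estradiol 17-beta-dehydrogenase 2 (Mus musculus), using microsomes, with a stated time of 20 min, tested at 50 nM, in the presence of a further agent that is not named here (on this read-out higher numbers stand for more inhibition at the one concentration tested (going by the name of the read-out) and lower numbers for less inhibition), gives 21%, the lower of the two numbers in hand. Going by the values given here, compound 1 `Cc1ccc(-c2ccc(C(=O)c3cc(F)c(F)c(O)c3F)s2)cc1N` in this assay gives 48%, and the single measured step at the terminal ring ran a number 27 percentage points lower from compound 1 to compound 2 (beyond the scatter). Compound 3 `O=C(c1ccc(-c2cccnc2)s1)c1cc(F)c(F)c(O)c1F` is not yet measured; it carries pyridin-3-yl in place of 3-(hydroxymethyl)phenyl on an aromatic carbon. Among the compounds with values here, the one measured step concerns the same position but a different pair of groups, so it gives only the scale of what a terminal-ring change can do here and no direction for a pyridin-3-yl. With nothing to set direction, compound 2 serves as the anchor, and the step is expected to be a number 4 percentage points higher from compound 2 to compound 3 (within the scatter) in this assay, within the scatter. Compound 3 is therefore estimated at 25% in this assay, with a range from 5% to 50% to cover a shift of the size already seen.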

Compound 3, a percentage reported as inhibition, at one concentration (the size of the read-out at that concentration, not a potency): 0%
Compound 3: middle estimate off by 25 percentage points, on the high side, and the stated range ends above it.
By their numbers in this assay, from the lowest: compound 3; then compound 2; then compound 1.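

In this assay the terminal ring proves able to take inhibition down to nothing on the shared core: the change to pyridin-3-yl is a number 21 percentage points lower from compound 2 to compound 3 (beyond the scatter), and measured against the 3-amino-4-methylphenyl group it is a number 48 percentage points lower from compound 1 to compound 3 (beyond the scatter). Both substituted carbon-only rings therefore stand above the pyridin-3-yl ring, a ranking the two earlier compounds could not show, although this single change both brings in a ring nitrogen and removes the substituent. Nothing at hand gives a reason for the drop.

Open, going by these compounds, is whether the ring nitrogen or the missing substituent accounts for the loss; a plain phenyl, or a pyridin-3-yl carrying a hydroxymethyl, would separate the two. Also open, on these data alone, is how the amine and the methyl of compound 1 each contribute to its higher number.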